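Swapping the acid of compound 1 for a hydroxyethyl amide

This account rests on a few compounds, and the source may have more. Where it says the series, first, only, none or still open, it means among the compounds named here.

Measured so far:
compound 1, `Cn1ncc(Cl)c1-c1cc(C(=O)N[C@@H]2CN[C@H](CC(=O)O)C[C@H]2c2ccc(Cl)c(Cl)c2)oc1Cl`: 1.94 nM
compound 2, `O=C(N[C@@H]1CNCC[C@H]1c1ccc(Cl)cc1)c1ccc(-c2ncnc3c2CCC3O)s1`: > 1000 nM, which is a limit of the assay

In an assay for inhibition of RAC-alpha serine/threonine-protein kinase (Homo sapiens), read by HTRF, with a stated time of 1 h (a higher number here means a weaker inhibitor, a lower number a stronger inhibitor), compound 1 gives 1.94 nM. For compound 2 the same assay reports only a limit, > 1000 nM, not a number. Among the measured compounds shown here, compound 1 therefore stands as the only numbered value here; the other entry is the limit of > 1000 nM in this assay, at which 1 of the 2 values shown sits.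

Compound 3, `Cn1ncc(Cl)c1-c1cc(C(=O)N[C@@H]2CN[C@H](CC(=O)NCCO)C[C@H]2c2ccc(Cl)c(Cl)c2)oc1Cl`, has not yet been measured. It differs from compound 1 in a single place: (2-hydroxyethyl)amino in place of hydroxy on a carbonyl carbon. For the measured compounds named here, no pair of measured compounds shows the effect of this change, so the expectation rests on compound 1 alone. The change is expected to weaken inhibition somewhat, with a step from a 3.1-fold higher number from compound 1 to compound 3 (0.49 log units; beyond the scatter) that is larger than the usual scatter but still moderate. Compound 3 is thus estimated at 6 nM, in a range from 1.5 nM to 30 nM.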

Compound 3, half-maximal inhibitory concentration: 1.41 nM
The estimate for compound 3 lay 4.3-fold (0.63 log units) above the measured number; measured number below the stated range.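

Putting (2-hydroxyethyl)amino in place of hydroxy on this carbonyl carbon gives a 1.4-fold lower number from compound 1 to compound 3 (0.14 log units; within the scatter) in this assay and so leaves the two compounds indistinguishable. Within this pair, the carboxy group of compound 1 is therefore not required for strong inhibition, and the larger (2-hydroxyethyl)carbamoyl group is accepted in its place. Nothing measured here accounts for why the swap is tolerated.

Going by these compounds, it remains open whether the hydroxy of the new chain contributes anything, which a plain ethyl amide or a simple primary amide at this carbonyl carbon would help to show. On these data alone, it is also open how much room this position offers, and a longer chain or one ending in an amine would test whether inhibition holds.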